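Dimethylamino in place of amino on the side chain

This account rests on a few compounds, and the source may have more. Where it says the series, first, only, none or still open, it means among the compounds named here.

In a functional assay on A549 cells (Homo sapiens) for antiproliferative activity, read by MTT assay, with a stated time of 48 h (on this read-out higher numbers stand for weaker inhibition and lower numbers for stronger inhibition), compound 2 (`COc1ccc(C(=O)c2ccc(OC)c3c2C=CC(C)(C)O3)c(NC(=O)CN)c1`) gives 420 nM as the middle of three numbers; compound 1 (`COc1ccc(C(=O)c2ccc(OC)c3c2C=CC(C)(C)O3)c(NC(=O)CO)c1`) gives 100 nM at the low end and compound 3 (`COc1ccc(C(=O)c2ccc(OC)c3c2OC(C)(C)C=C3)c(NC(=O)CN(C)C)c1`) gives 890 nM at the high end. The next case is compound 4 (`COc1ccc(C(=O)c2ccc(OC)c3c2C=CC(C)(C)O3)c(NC(=O)CN(C)C)c1`), reached from compound 2 by dimethylamino in place of amino on a saturated chain carbon bound to a carbonyl carbon with dimethylamino in place of amino on a saturated chain carbon bound to a carbonyl carbon. Within the data shown here, the only measured step at this carbon is a 4.2-fold higher number from compound 1 to compound 2 (0.62 log units; beyond the scatter) and it is modest. Among the measured compounds shown here, compound 3 also bears dimethylamino, on a differently arranged core, and its 890 nM is the highest number so far. A modest rise, toward weaker inhibition, is therefore expected, estimated as a 1.5-fold higher number from compound 2 to compound 4 (0.17 log units; within the scatter) for now. The estimate for compound 4 is 620 nM with an expected range of 240 nM to 1500 nM in this assay for this read-out.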

Compound 4, half-maximal inhibitory concentration: 1850 nM
Estimate against measurement, compound 4: 3.0-fold (0.47 log units) below, and the stated range ends below it.
By their numbers in this assay, from the lowest: compound 1; then compound 2; then compound 3; then compound 4.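

On the saturated chain carbon bound to a carbonyl carbon, dimethylamino in place of amino gives (a 4.4-fold higher number from compound 2 to compound 4 (0.64 log units; beyond the scatter)) in this assay, a step of about the same size as (a 4.2-fold higher number from compound 1 to compound 2 (0.62 log units; beyond the scatter)), so numbers rise from hydroxy through amino to dimethylamino on the shared core of compounds 1, 2 and 4. Across the whole span, dimethylamino in place of hydroxy gives (a 19-fold higher number from compound 1 to compound 4 (1.27 log units; beyond the scatter)). No measurement shown offers a reason for this order.

Open, going by these compounds, is where methylamino, a carboxylic acid or a longer chain ending in hydroxy would fall at this carbon.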